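One Change at the Double-Bonded Chain Carbon

This account rests on a few compounds, and the source may have more. Where it says the series, first, only, none or still open, it means among the compounds named here.

Measured so far:
compound 1, `CN(C)c1ccc(/C=C(/SCc2ccc(F)cc2)C(=O)c2ccc(Br)cc2)cc1`, gives 50000 nM
compound 2, `O=C(/C(=C\c1ccc(O)cc1O)SCc1cccc(Cl)c1)c1ccc(Br)cc1`, gives 50000 nM

In a functional assay on DU-145 cells (Homo sapiens) for inhibition, read by trypan blue exclusion, with a stated time of 96 h (a higher number here means a weaker inhibitor of growth, a lower number a stronger inhibitor of growth), compound 1 gives 50000 nM. In this assay compound 2 gives 50000 nM. On the two numbers shown, compound 1 stands level with compound 2 at the digits printed, and the two compounds cannot be told apart within the scatter. Neither compound shows any growth inhibition of note at the concentrations reached.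

Compound 3, `O=C(/C(=C\c1ccc2ccccc2n1)SCc1ccc(F)cc1)c1ccc(Br)cc1`, has not yet been measured. It differs from compound 1 in one place: quinolin-2-yl in place of 4-(dimethylamino)phenyl on a double-bonded chain carbon bound to a double-bonded chain carbon. The shared core of compound 1 and compound 3 stays the same, and only the group on that double-bonded chain carbon is exchanged.

Within the data shown here, no step between measured compounds is available to guide this exchange, so the size of the step in this assay is uncertain. Given that compound 1 and compound 2, which differ at the same part of the molecule, both give the same weak result, the most likely outcome for compound 3 is again a weak one, with a modest chance of a gain in growth inhibition. The step from compound 1 to compound 3 is expected to be a 1.7-fold lower number from compound 1 to compound 3 (0.22 log units; within the scatter). For compound 3 the estimate in this assay is 30000 nM, with a range from 6000 nM to 50000 nM.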

Compound 3, concentration for 50% growth inhibition: 25000 nM
Beside the measured number, compound 3's estimate is 1.2-fold (0.08 log units) above it, and the stated range covers the measured number.
By their numbers in this assay, from the lowest: compounds 3, 1 and 2 (each within the scatter of the next).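

In this assay, among these compounds, quinolin-2-yl in place of 4-(dimethylamino)phenyl on a double-bonded chain carbon bound to a double-bonded chain carbon gives a 2.0-fold lower number from compound 1 to compound 3 (0.30 log units; within the scatter), and this is the first step that can be read at this place in the molecule. The exchange removes the dimethylamino group and brings in a second six-membered aromatic ring, one with a hetero atom, while the count of hydrogen-bond acceptors stays the same and neither group carries a net charge; even so, the step does not leave the scatter. For this one pair, then, a change of this kind in the ring system at this place cannot be told from no change at all, and nothing measured alongside these numbers bears on the result.

The compounds shown leave open whether any group at this place can move the number beyond the scatter, for example a pyridin-2-yl group or a quinolin-2-yl group carrying a carboxylic acid. They also leave open whether the same exchange would give a step of this size if the shared core carried an amine in place of the bromine.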